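The source may report more compounds than this note shows. Statements on the series, on what has been measured and on what is new or still open speak of the compounds shown alone.

Working notes on the series

Of the compounds shown here, three have been measured in a functional assay for agonist activity at Free fatty acid receptor 1 (Homo sapiens), read by FLIPR, in the presence of a further agent that is not named here; a higher number here means that more compound is needed for the effect, a lower number that less compound is needed. Compound 1 `Cc1cc(Oc2ccc(CC3SC(=O)NC3=O)cc2)nc(C(F)(F)F)c1` gives 688 nM. Compound 2 `O=C1NC(=O)C(Cc2ccc(Oc3cccc(C(F)(F)F)n3)cc2)S1` gives 1640 nM. Compound 3 `Cc1ccc(Oc2ccc(CC3SC(=O)NC3=O)cc2)cc1` gives 547 nM; the numbers for compound 3 and compound 1 lie within the usual scatter of each other, and the number for compound 2 is higher than both.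

One single-point change is measured. Compound 2 and compound 1 differ by methyl in place of hydrogen on an aromatic carbon, and this change gave a 2.4-fold lower number from compound 2 to compound 1 (0.38 log units; beyond the scatter). Compound 3 and compound 2 differ in more than one place, so the difference between the two cores is not broken down here.

Compound 4 `Cc1ccc(Oc2ccc(CC3SC(=O)NC3=O)cc2)c(C)c1` is not yet measured. It differs from compound 3 by methyl in place of hydrogen on an aromatic carbon. This is the same kind of change as that from compound 2 to compound 1, but not the same: in compound 1 the methyl enters on a six-membered aromatic ring with one nitrogen, meta to a large group, meta to a trifluoromethyl group and opposite the ring nitrogen, whereas in compound 4 it enters on a six-membered aromatic ring of carbon only, ortho to a large group and meta to a methyl group.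

Given that the only measured instance of this kind of change, from compound 2 to compound 1, gave a 2.4-fold lower number from compound 2 to compound 1 (0.38 log units; beyond the scatter), a step of similar direction but kept smaller is expected for compound 4: a 1.4-fold lower number from compound 3 to compound 4 (0.14 log units; within the scatter). Compound 4 is therefore estimated at 400 nM in this assay, with the range 150 nM to 1000 nM.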

Compound 4, half-maximal effective concentration: 121 nM
The estimate for compound 4 lay 3.3-fold (0.52 log units) above the measured number, outside the stated range (below it).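

In this assay, methyl in place of hydrogen on an aromatic carbon again lowered the number, this time on a six-membered aromatic ring of carbon only, with a 4.5-fold lower number from compound 3 to compound 4 (0.66 log units; beyond the scatter). Set beside the earlier case, the two steps run in the same direction and cannot be told apart in size, so on these two cores the change carries over with no measurable difference: the same change on two cores in this assay, a 2.4-fold lower number (0.38 log units; beyond the scatter) from compound 2 to compound 1 and a 4.5-fold lower number (0.66 log units; beyond the scatter) from compound 3 to compound 4, 1.9-fold (0.28 log units) apart, within the scatter of two such steps. Going by these compounds alone, this is only two steps, and the methyl enters a different kind of ring in each pair, so it does not show that the change would carry to other cores or other ring positions, nor does it separate the contribution of the core from that of the place of substitution.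

The compounds shown leave open whether a chlorine atom, a methoxy group or a longer chain at the same aromatic carbon would give a step in the same direction, and whether the step in compound 4 depends on the methyl group already on that ring. On these data alone, it is also open whether the step would persist on a core carrying a carboxylic acid or an amine.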